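The source may hold more compounds than are shown below. What is called first, only, known or untested is meant among the compounds shown, and "the series" means these compounds.

In a functional assay on K562 cells (Homo sapiens) for inhibition, read by trypan blue exclusion, with a stated time of 72 h (a higher number here means a weaker inhibitor, a lower number a stronger inhibitor), the measured compounds read as follows:

compound 1 `Cn1c(=O)c(S(=O)(=O)c2ccc(F)cc2)cc2cnc(Nc3ccc4occc4c3)nc21` gives 5000 nM
compound 2 `Cn1c(=O)c(S(=O)(=O)c2ccc(F)cc2F)cc2cnc(Nc3ccc4occc4c3)nc21` gives 15000 nM
compound 3 `Cc1ccc(S(=O)(=O)c2cc3cnc(Nc4cccc5cccnc45)nc3n(C)c2=O)cc1` gives 10000 nM

Compound 1 stands at the lowest number of the three. Compound 3 lies within the usual scatter of it, so the two cannot be ordered; compound 2 lies beyond the scatter, at the weaker end. Going by the values given here, the only single-point step in the set, a 3.0-fold higher number from compound 1 to compound 2 (0.48 log units; beyond the scatter), concerns fluoro in place of hydrogen on an aromatic carbon and leaves the arylamine untouched.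

Compound 4 `Cn1c(=O)c(S(=O)(=O)c2ccc(F)cc2)cc2cnc(Nc3ccc4cc[nH]c4c3)nc21` differs from compound 1 by 1H-indol-6-yl in place of 1-benzofuran-5-yl on a nitrogen on an aromatic ring. Among the compounds with values here, no measured step bears on this exchange: compound 3 carries another arylamine, but it differs from compound 1 in more than one place, so its value shows only that the number stays near that of compound 1. The exchange keeps the size of the group and swaps one hydrogen-bond acceptor for one hydrogen-bond donor. With nothing in the data to point either way, the expected step is none beyond the scatter: a 1.1-fold lower number from compound 1 to compound 4 (0.05 log units; within the scatter). Compound 4 is therefore estimated at 4500 nM, with a range from 1500 nM to 14000 nM.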

Compound 4, half-maximal inhibitory concentration: 10000 nM
Compound 4: middle estimate off by 2.2-fold (0.35 log units), on the low side; the range from low to high includes it.
By their numbers in this assay, from the lowest: compounds 1, 3, 4 and 2 (each within the scatter of the next, the first and the last beyond it).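

In this assay, going by these compounds alone, the exchange gives the first reading at this position that differs in one place only: 1H-indol-6-yl in place of 1-benzofuran-5-yl, on a nitrogen on an aromatic ring, gives a 2.0-fold higher number from compound 1 to compound 4 (0.30 log units; within the scatter) and so does not separate the two groups. The exchange carries two changes at once, the ring hetero atom and the point of attachment, and a hydrogen-bond acceptor leaves as a hydrogen-bond donor enters, so no single one of these can be read alone. Nothing measured here gives a reason for this result.

As far as these compounds go, it remains open whether any group on this nitrogen, such as a phenyl ring carrying a piperazine or a morpholine, moves the number clearly away from that of compound 1. From the compounds shown here alone, it is also open whether the step seen with the added fluoro group holds when 1H-indol-6-yl is present.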